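Amide variation on the urotensin receptor series

The source may report more compounds than this note shows. Statements on the series, on what has been measured and on what is new or still open speak of the compounds shown alone.

Compound 1, `COc1ccc(C(=O)N[C@H]2CCN(Cc3ccc(OCCCN(C)C)cc3)C2)cc1OC` — in an assay on HEK293 cells for binding affinity to Urotensin-2 receptor (Homo sapiens), read by radioligand binding (on this read-out lower numbers stand for stronger inhibition and higher numbers for weaker inhibition), compound 1 gives only a limit, < 10000 nM.
Compound 2, `Cc1cc(C(=O)N[C@H]2CCN(Cc3ccc(OCCCN(C)C)cc3)C2)ccc1Br` — compound 2 gives 631 nM.
Compound 3, `CN(C)CCCOc1ccc(CN2CC[C@H](NC(=O)c3ccncc3)C2)cc1` — compound 3 gives only a limit, < 10000 nM.

Compound 1 stands at a limit of the assay, not at a number, so its place among the three cannot be fixed. The step that the limit leaves unreadable from compound 1 to compound 2 is therefore unreadable, as are a step that the two limits leave unreadable from compound 1 to compound 3 and a step that the limit leaves unreadable from compound 2 to compound 3; this follows from the limit of < 10000 nM in this assay, at which 2 of the 3 values shown sit. Only compound 2 gives a measured number.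

Compound 4, `CN(C)CCCOc1ccc(CN2CC[C@H](NC(=O)c3cc4ccccc4o3)C2)cc1`, differs from compound 1 by 1-benzofuran-2-yl in place of 3,4-dimethoxyphenyl on a carbonyl carbon. Going by the values given here, none of the measured steps bears readably on this change, so no direction beyond the scatter can be derived from them. Among the compounds with values here, the closest point of reference is compound 2, the only numbered value, which carries a lipophilic aryl on the same carbonyl carbon.

Compound 4 is expected to give 1500 nM, between 200 nM and 10000 nM. Against compound 1 this expectation corresponds to a step that the limit leaves unreadable from compound 1 to compound 4, which cannot be checked against a limit.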

Compound 4, inhibition constant: 2510 nM
Compound 4: the middle estimate sits 1.7-fold (0.22 log units) below what was measured; the range from low to high includes it.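

Going by these compounds alone, on the carbonyl carbon, two groups now carry numbers in this assay, so a change at this position has a readable size for the first time: a 4.0-fold higher number from compound 2 to compound 4 (0.60 log units; beyond the scatter). A measured number here is therefore not confined to 4-bromo-3-methylphenyl, since 1-benzofuran-2-yl also gives one, although the number for compound 4 is the higher of the two. The steps to compound 4 from compound 1 and from compound 3 cannot be read: the limit of < 10000 nM in this assay, at which 2 of the 4 values shown sit.

Going by these compounds, compound 2 and compound 4 differ in the whole group, so the shares of the bromine, the methyl and the ring system in this step remain open. On these data alone, how a plain phenyl or a 4-bromophenyl group would compare on the same carbonyl carbon also remains open.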